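Changing the Far-End Aryl Group of Compound 2

This account rests on a few compounds, and the source may have more. Where it says the series, first, only, none or still open, it means among the compounds named here.

Compound 2 `C#CCOc1cccc(/C=C/C(=O)Nc2cc(C(=O)c3cc(OC)c(OC)c(OC)c3)cc(OC)c2OC)c1` gives the higher of the two numbers measured in a functional assay on B16 cells (Mus musculus) for cytotoxicity, read by MTT assay, with a stated time of 72 h (a lower number here means a stronger inhibitor, a higher number a weaker inhibitor), at 5100 nM, while compound 1 `COc1ccc(C(=O)c2cc(OC)c(OC)c(OC)c2)cc1NC(=O)/C=C/c1ccc(C(F)(F)F)cc1` gives 100 nM in this assay. Compound 3 `COc1cc(C(=O)c2cc(OC)c(OC)c(OC)c2)cc(NC(=O)/C=C/c2ccc(C(F)(F)F)cc2)c1OC` differs from compound 2 by 4-(trifluoromethyl)phenyl in place of 3-(propargyloxy)phenyl on a double-bonded chain carbon bound to a double-bonded chain carbon; compound 1 carries that same entering group on a different core, and no direct comparison between the two cores exists. The step of an 8.5-fold lower number from compound 2 to compound 3 (0.93 log units; beyond the scatter) is expected to be a drop beyond the scatter, though smaller than the gap between the two measured compounds. Compound 3 is therefore estimated at 600 nM, within 120 nM to 3000 nM.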

Compound 3, half-maximal inhibitory concentration: 3300 nM
The estimate for compound 3 lay 5.5-fold (0.74 log units) below the measured number; measured number above the stated range.
By their numbers in this assay, from the lowest: compound 1; then compounds 3 and 2 (each within the scatter of the next).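

In this assay, changing the far-end aryl group gives a 1.5-fold lower number from compound 2 to compound 3 (0.19 log units; within the scatter), within the scatter, so 4-(trifluoromethyl)phenyl and 3-(propargyloxy)phenyl cannot be told apart at this position on the core of compound 3. The large step lies elsewhere: methoxy in place of hydrogen on an aromatic carbon gives a 33-fold higher number from compound 1 to compound 3 (1.52 log units; beyond the scatter), beyond the scatter. Nothing available explains the size of either step. Still open, going by these compounds, is whether a far-end phenyl carrying an amine or a carboxylic acid would give a different number, and whether the aryl change would matter on the core of compound 1.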